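The source may hold more compounds than are shown below. What is called first, only, known or untested is meant among the compounds shown, and "the series" means these compounds.

Among the three measured compounds, compound 3 (`O=C(C1CCCCC1)N1CCC2(CCN(c3nccc(NCc4ccc(Cl)cc4Cl)n3)CC2)C1`) stands lowest in a physicochemical assay for solubility, read by chemiluminescence, measured as kinetic solubility (a higher number here means a more soluble compound, a lower number a less soluble compound), at 3 ug/mL. Compound 1 (`O=C([C@H]1CCCCN1)N1CCC2(CCN(c3nccc(NCc4ccc(Cl)cc4Cl)n3)CC2)C1`) gives 172 ug/mL, and compound 2 (`O=C(C1CCCNC1)N1CCC2(CCN(c3nccc(NCc4ccc(Cl)cc4Cl)n3)CC2)C1`) gives 186 ug/mL. The next compound to be tested, compound 4 (`Clc1ccc(CNc2ccnc(N3CCC4(CCN(C[C@H]5CCCN5)C4)CC3)n2)c(Cl)c1`), differs from compound 3 by one replacement: (pyrrolidin-2-yl)methyl in place of cyclohexylcarbonyl on an amine nitrogen in a ring.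

Going by the values given here, two measured steps bear most directly on this change. Putting cyclohexyl in place of piperidin-2-yl on a carbonyl carbon gave a 57-fold lower number from compound 1 to compound 3 (1.76 log units; beyond the scatter), and putting it in place of piperidin-3-yl gave a 62-fold lower number from compound 2 to compound 3 (1.79 log units; beyond the scatter). Both steps are large, and they agree closely. Moving between the two piperidine groups made little difference, with a 1.1-fold higher number from compound 1 to compound 2 (0.03 log units; within the scatter). So, in these three compounds, the two groups with a nitrogen in the ring sit far higher than the all-carbon ring, whichever of the two is present.

Compound 4 also swaps the cyclohexyl ring for a ring holding a nitrogen, but its group is a (pyrrolidin-2-yl)methyl on the amine nitrogen, and it has no carbonyl there. Among the compounds with values here, none of the measured compounds lacks that carbonyl, so this evidence is indirect. A large rise in this assay is therefore expected, and the estimated step is a 43-fold higher number from compound 3 to compound 4 (1.64 log units; beyond the scatter). Compound 4 is estimated at 130 ug/mL, with an expected range from 40 ug/mL to 300 ug/mL.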

Compound 4, solubility: 16 ug/mL
Beside the measured number, compound 4's estimate is 8.1-fold (0.91 log units) above it; measured number outside the range, below it.
By their numbers in this assay, from the lowest: compound 3; then compound 4; then compounds 1 and 2 (each within the scatter of the next).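

In this assay, putting (pyrrolidin-2-yl)methyl in place of cyclohexylcarbonyl on this amine nitrogen gives a 5.3-fold higher number from compound 3 to compound 4 (0.73 log units; beyond the scatter) as a modest gain, so a group with a nitrogen in its ring can raise the number here even with no carbonyl attached to that nitrogen. The same group still falls well short of the two piperidine amides, giving a 12-fold lower number from compound 2 to compound 4 (1.07 log units; beyond the scatter) and an 11-fold lower number from compound 1 to compound 4 (1.03 log units; beyond the scatter) as large drops, so a nitrogen in the ring does not by itself reach the level of those two compounds. No measurement on hand accounts for this shortfall.

The change from compound 1 to compound 4 alters both the ring, from six-membered to five-membered, and the link, from carbonyl to a methyl-derived carbon, and only a matched pair such as (pyrrolidin-2-yl)carbonyl or (piperidin-2-yl)methyl on the same nitrogen could show which of the two matters more. As far as these compounds go, how an open-chain amine or a carboxylic acid would behave at this position also remains open.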